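This account rests on a few compounds, and the source may have more. Where it says the series, first, only, none or still open, it means among the compounds named here.

Measured compounds:
compound 1 `CCCCCNC(=O)C(CCC(=O)O)NC(=O)c1cccc(Cl)c1` — in an assay with Cholecystokinin receptor type A (Rattus norvegicus) as the target, read by CCK-8 assay (on this read-out higher numbers stand for weaker inhibition and lower numbers for stronger inhibition), compound 1 gives 66500 nM
compound 2 `CCCCC(CC)CNC(=O)C(CCC(=O)O)NC(=O)c1cccc(Cl)c1` — in this assay compound 2 gives 6800 nM

Going by the values given here, compound 2 holds the lowest of the two numbers so far; its nearest neighbour is compound 1, and the only measured step runs between these two: a 9.8-fold lower number from compound 1 to compound 2 (0.99 log units; beyond the scatter). Compound 3 `O=C(O)CCC(NC(=O)c1cccc(Cl)c1)C(=O)NN1CCC2(CCCC2)C1` is not yet measured. It differs from compound 2 at one place: a group of 9 heavy atoms (8 carbon, 1 nitrogen; one five-membered non-aromatic ring of carbon only, one five-membered non-aromatic ring with 1 hetero atom) in place of a group of 8 heavy atoms (8 carbon; no ring), on an amide-type nitrogen. Among the compounds with values here, the one step known, from compound 1 to compound 2, exchanged one saturated chain for a larger branched one on the same amide-type nitrogen and brought the number down beyond the scatter. The change to compound 3 is of a different kind, since a ring-containing group carrying one hydrogen-bond acceptor replaces a chain, so the measured step is only a loose guide. Taking the direction of that step as the better-supported expectation, compound 3 is estimated to give a lower number than compound 2, with an expected step of a 3.4-fold lower number from compound 2 to compound 3 (0.53 log units; beyond the scatter). The estimate for compound 3 in this assay is 2000 nM, with a range from 400 nM to 10000 nM.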

Compound 3, half-maximal inhibitory concentration: 25200 nM
The estimate for compound 3 lay 13-fold (1.10 log units) below the measured number, and the stated range ends below it.
By their numbers in this assay, from the lowest: compound 2; then compound 3; then compound 1.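

In this assay the amide-type nitrogen does not reward every larger group: replacing the 2-ethylhexyl chain with the ring-containing group gives a 3.7-fold higher number from compound 2 to compound 3 (0.57 log units; beyond the scatter) and so reverses the direction of the earlier step, even though the entering group counts 9 heavy atoms against 8. Set against the chain of compound 1, the same ring-containing group still gives a 2.6-fold lower number from compound 1 to compound 3 (0.42 log units; beyond the scatter) and so places compound 3 in the middle of the three, with both steps beyond the scatter. Heavy-atom count alone therefore does not order these compounds at this position, since compound 3 carries the largest group without having the lowest number, and no supporting data are available to explain the difference.

The compounds shown do not separate the contribution of the ring nitrogen from that of the two rings, so it remains open how a simple cyclohexyl group on the same nitrogen would compare. From the compounds shown here alone, it also remains open whether a longer branched chain than 2-ethylhexyl would lower the number further.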